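The source may hold more compounds than are shown below. What is called first, only, known or untested is meant among the compounds shown, and "the series" means these compounds.

Compound 1 `O=C(/C=C/c1ccc2c(c1)B(O)OC2)c1ccc(F)cc1` is one of three close analogues that share a core and differ only in the ring group on the carbonyl carbon. In a toxicity assay on MCF-10A cells (Homo sapiens) for cytotoxicity, read by MTT assay, with a stated time of 48 h (a higher number here means a weaker inhibitor, a lower number a stronger inhibitor), compound 1 gives 11800 nM, the smallest of the three numbers. That standing means little, since every step among them is within the scatter. Compound 2 `O=C(/C=C/c1ccc2c(c1)B(O)OC2)c1ccc(C(F)(F)F)cc1` gives 22300 nM and compound 3 `CCOC(=O)c1ccc(C(=O)/C=C/c2ccc3c(c2)B(O)OC3)cc1` gives 12900 nM; the steps of a 1.9-fold higher number from compound 1 to compound 2 (0.28 log units; within the scatter), a 1.1-fold higher number from compound 1 to compound 3 (0.04 log units; within the scatter) and a 1.7-fold lower number from compound 2 to compound 3 (0.24 log units; within the scatter) all stay within the scatter. Compound 4 `O=C(/C=C/c1ccc2c(c1)B(O)OC2)c1cccc(F)c1` differs from compound 1 by 3-fluorophenyl in place of 4-fluorophenyl on a carbonyl carbon. For the measured compounds named here, no measured step moves a fluorine within that ring; the measured steps exchange one group for another and none reached beyond the scatter, so no step beyond the scatter is expected here. Compound 4 is therefore expected to give about 12000 nM in this assay, with a range from 5000 nM to 30000 nM. The expected step is a 1.0-fold higher number from compound 1 to compound 4 (0.01 log units; within the scatter).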

Compound 4, half-maximal inhibitory concentration: 15800 nM
Estimate against measurement, compound 4: 1.3-fold (0.12 log units) below, within the range that was stated.
By their numbers in this assay, from the lowest: compounds 1, 3, 4 and 2 (each within the scatter of the next).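

Moving the fluorine, with 3-fluorophenyl in place of 4-fluorophenyl on the carbonyl carbon, is the first step here that keeps the same atoms and only joins them differently. In this assay it gives a 1.3-fold higher number from compound 1 to compound 4 (0.13 log units; within the scatter) and so, among these compounds, the fluorine's place on this ring has no effect that can be told from the scatter. Nothing available here bears on this result. Still open, from the compounds shown here alone, is whether an amine or a carboxylic acid on this ring would also stay within the scatter of compound 1.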